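This account rests on a few compounds, and the source may have more. Where it says the series, first, only, none or still open, it means among the compounds named here.

In a physicochemical assay for solubility (a higher number here means a more soluble compound, a lower number a less soluble compound), two compounds sharing one core have been measured so far. Compound 1 `O=C1OCCN1c1cc(C(F)(F)F)ccc1[C@H]1CCOc2cc(S(=O)(=O)Nc3nccs3)ccc21` gives 295000 nM, and compound 2 `Cc1nc(-c2cc(C(F)(F)F)ccc2[C@H]2CCOc3cc(S(=O)(=O)Nc4nccs4)ccc32)co1` gives 61000 nM, the lower of the two numbers. The next structure, compound 3 `O=S(=O)(Nc1nccs1)c1ccc2c(c1)OCC[C@@H]2c1ccc(C(F)(F)F)cc1-c1ccc(F)cn1`, keeps the core of compound 2 but changes one group: 5-fluoropyridin-2-yl takes the place of 2-methyl-1,3-oxazol-4-yl on an aromatic carbon (5-fluoropyridin-2-yl in place of 2-methyl-1,3-oxazol-4-yl on an aromatic carbon). That carbon belongs to a six-membered aromatic ring of carbon only and is meta to a trifluoromethyl group.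

Going by the values given here, only one measured step bears on this change. Putting 2-methyl-1,3-oxazol-4-yl in place of 2-oxo-1,3-oxazolidin-3-yl gave a 4.8-fold lower number from compound 1 to compound 2 (0.68 log units; beyond the scatter), a modest step beyond the scatter. It involves a different pair of groups, and one step sets no pattern, so it serves only as a rough guide to size. Among the compounds with values here, no measurement yet compares the two aromatic rings directly. On the evidence of that one step, a further modest fall is expected, and the estimated change is a 2.0-fold lower number from compound 2 to compound 3 (0.31 log units; beyond the scatter). The estimate for compound 3 is 30000 nM, with an expected range from 9000 nM to 90000 nM.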

Compound 3, solubility: 7000 nM
Compound 3: middle estimate off by 4.3-fold (0.63 log units), on the high side, and the stated range ends above it.
By their numbers in this assay, from the lowest: compound 3; then compound 2; then compound 1.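

Going by these compounds alone, compounds 2 and 3 give the first direct comparison of two aromatic rings on this carbon, which is ortho to a large group and meta to a trifluoromethyl group: in this assay, the change gives an 8.7-fold lower number from compound 2 to compound 3 (0.94 log units; beyond the scatter), a second modest fall in the same direction as a 4.8-fold lower number from compound 1 to compound 2 (0.68 log units; beyond the scatter). Taken end to end, the three groups give a 42-fold lower number from compound 1 to compound 3 (1.62 log units; beyond the scatter), a large step, so changing this one group while the rest of the structure stays the same can move the number a long way. Nothing available here gives a reason for either fall.

The step to compound 3 changes several things at once: a five-membered aromatic ring becomes a six-membered one, the hetero atoms differ, and a fluorine enters, so the compounds shown cannot separate these features, and a pyridin-2-yl group without the fluorine would help to do so. As far as these compounds go, it also remains open how this position would respond to a group without a ring, such as an amine, a carboxylic acid or a longer chain.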